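A few compounds are considered here, and "the series" means these few. Any claim that something is new, unique, unknown or untested is made for them only; others in the source may bear on it.

Compound 1 `CC1C(=O)N(C)c2cnc(Nc3ccc(S(N)(=O)=O)cc3)nc2N1C`: 313 nM
Compound 2 `CC(C)CC1C(=O)N(C)c2cnc(Nc3ccc(S(N)(=O)=O)cc3)nc2N1C`: 77 nM
Compound 3 `CN1C(=O)C(c2cccc(F)c2)N(C)c2nc(Nc3ccc(S(N)(=O)=O)cc3)ncc21`: 134 nM

Three analogues of the shared core have been measured in an assay on Sf9 cells for inhibition of serine/threonine-protein kinase 4 (Homo sapiens), read by luminescence and ADP-Glo, with a stated time of 1 h, in the presence of a further agent that is not named here (on this read-out higher numbers stand for weaker inhibition and lower numbers for stronger inhibition), where compound 3 gives 134 nM. Among the three numbers, compound 3 stands second highest. Its nearest neighbour is compound 2, with a 1.7-fold higher number from compound 2 to compound 3 (0.24 log units; within the scatter); the furthest is compound 1, with a 2.3-fold lower number from compound 1 to compound 3 (0.37 log units; beyond the scatter).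

Compound 4 `CCc1ccccc1C1C(=O)N(C)c2cnc(Nc3ccc(S(N)(=O)=O)cc3)nc2N1C` carries the change (2-ethylphenyl in place of 3-fluorophenyl on a saturated ring carbon). Among the compounds with values here, two measured steps touch the same position: from compound 1 to compound 3 the aromatic group in place of methyl gave a 2.3-fold lower number from compound 1 to compound 3 (0.37 log units; beyond the scatter), and from compound 2 to compound 3 the exchange of isobutyl for the aromatic group gave a 1.7-fold higher number from compound 2 to compound 3 (0.24 log units; within the scatter). Within the data shown here, no step from one aromatic group to another has been measured, so the effect of the pattern on the ring is unknown. Both known steps at this carbon are modest at most, and the aromatic group has held the number near the lower end of the series. For the move to compound 4 no step beyond the scatter is expected in this assay, a 1.0-fold lower number from compound 3 to compound 4 (0.01 log units; within the scatter). Compound 4 is therefore estimated at 130 nM, with a likely range from 50 nM to 350 nM.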

Compound 4, half-maximal inhibitory concentration: 51 nM
Compound 4: middle estimate off by 2.5-fold (0.41 log units), on the high side; the measured number falls inside the stated range.
By their numbers in this assay, from the lowest: compounds 4, 2 and 3 (each within the scatter of the next, the first and the last beyond it); then compound 1.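

In this assay, within the data shown here, the aromatic group on this saturated ring carbon is not interchangeable: the only step between two aromatic groups, 2-ethylphenyl in place of 3-fluorophenyl, gives a 2.6-fold lower number from compound 3 to compound 4 (0.42 log units; beyond the scatter) and lies beyond the scatter. Against methyl, 2-ethylphenyl gives a 6.1-fold lower number from compound 1 to compound 4 (0.79 log units; beyond the scatter) and is the largest step at this carbon so far, while against isobutyl it gives a 1.5-fold lower number from compound 2 to compound 4 (0.18 log units; within the scatter) and the two groups cannot be told apart on these numbers. The step to compound 4 changes both the substituent and its place on the phenyl ring, and the compounds shown do not separate the two.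

Open, on these data alone, is how phenyl without a substituent, 2-fluorophenyl, 3-ethylphenyl or cyclohexyl would read at this carbon. Nothing available accounts for the step from 3-fluorophenyl to 2-ethylphenyl.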